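This account rests on a few compounds, and the source may have more. Where it says the series, first, only, none or still open, it means among the compounds named here.

Measured so far:
- compound 1 `C=CCOc1ccc2c(=O)c(-c3cc(OC)c(OC)cc3OC)coc2c1` gives 5100 nM
- compound 2 `COc1ccc2c(=O)c(-c3cc(OC)c(OC)cc3OC)coc2c1` gives 5200 nM

Both numbers come from a functional assay on B16 cells (Mus musculus) for antiproliferative activity, read by MTT assay, with a stated time of 24 h; a higher number here means a weaker inhibitor, a lower number a stronger inhibitor. Compound 1 holds the lowest of the two numbers, and its nearest neighbour is compound 2, the two lying within the scatter of each other. Going by the values given here, the only step measured here, a 1.0-fold higher number from compound 1 to compound 2 (0.01 log units; within the scatter), changes the same place that the new compound changes, and it did not move the number beyond the scatter.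

Compound 3 `COc1cc(OC)c(-c2coc3cc(OCC(=O)c4cccc(C(F)(F)F)c4)ccc3c2=O)cc1OC` is the unmeasured one. It differs from compound 1 by (3-(trifluoromethyl)phenyl)carbonyl in place of vinyl on a saturated chain carbon bound to an oxygen on an aromatic ring. Among the compounds with values here, the one measured step at this place was flat, but it removed a small group, while here a much larger group enters, so that step is only a weak guide. With nothing else to go on, the step of a 1.1-fold lower number from compound 1 to compound 3 (0.05 log units; within the scatter) is expected to stay within the scatter, with a wide range. Compound 3 is therefore estimated at 4500 nM, between 900 nM and 22000 nM.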

Compound 3, half-maximal inhibitory concentration: > 10000 nM
Compound 3 ended at the assay's limit; the forecaster's own chance of this, stated with the estimate: 10%; at least 2.2-fold (0.34 log units) between middle value and limit.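

In this assay the reading for compound 3 is a limit of the assay and not a number: the limit of > 10000 nM in this assay, at which 1 of the 3 values shown sits. Putting the much larger (3-(trifluoromethyl)phenyl)carbonyl in place of vinyl gives an at least 1.9-fold higher number from compound 1 to compound 3 (0.29 log units; that floor lies within the scatter), and putting it in place of hydrogen gives an at least 1.9-fold higher number from compound 2 to compound 3 (0.28 log units; that floor lies within the scatter). The small groups of compound 1 and compound 2 said nothing about a group of this size, and these steps now show that it brings no measurable gain here, though both floors lie within the scatter, so a real loss is not established.

Going by these compounds, how far compound 3 lies past the limit remains unknown, as does whether the carbonyl or the aromatic ring matters more. Also open, on these data alone, is whether an amine, a carboxylic acid or a longer chain at this place would move the number beyond the scatter.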